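Aryl-ether imidazolines: five-membered ring swap at the ether-bearing arene

The compounds below may be only part of what the source reports. "The series", "measured", "known", "first", "only" and "open" are said of these compounds alone.

Measured compounds:
compound 1 `c1csc(-c2ccccc2OCC2=NCCN2)c1` gives 1 nM in a functional assay for activation of Alpha-1A adrenergic receptor (Homo sapiens), read by calcium flux; on this read-out higher numbers stand for an effect only at larger amounts of compound and lower numbers for an effect already at smaller amounts
compound 2 `c1ccc(-c2cc[nH]n2)c(OCC2=NCCN2)c1` gives 5.01 nM in this assay

Among the compounds with values here, compound 2 holds the highest of the two numbers in this assay; the only measured step, a 5.0-fold higher number from compound 1 to compound 2 (0.70 log units; beyond the scatter), separates it from compound 1.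

Compound 3 `c1ccc(-c2nccs2)c(OCC2=NCCN2)c1` is not yet measured. It differs from compound 2 by 1,3-thiazol-2-yl in place of 1H-pyrazol-3-yl on an aromatic carbon. Within the data shown here, the ring that enters carries sulfur, as does the ring of compound 1, but no measured pair compares a thiazole with a pyrazole, so the step of a 5.0-fold higher number from compound 1 to compound 2 (0.70 log units; beyond the scatter) bears on the change only indirectly. With compound 1 at 1 nM and compound 2 at 5.01 nM, compound 3 is expected to fall between them, nearer compound 1; the expected step is a 2.5-fold lower number from compound 2 to compound 3 (0.40 log units; beyond the scatter). The estimate for compound 3 in this assay is 2 nM, expected to lie within 0.6 nM to 8 nM.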

Compound 3, half-maximal effective concentration: 2.51 nM
Compound 3: the middle estimate sits 1.3-fold (0.10 log units) below what was measured; measured number inside the range.
By their numbers in this assay, from the lowest: compound 1; then compounds 3 and 2 (each within the scatter of the next).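

In this assay, the position on the aromatic carbon ortho to a group of 7 heavy atoms takes 1,3-thiazol-2-yl in place of 1H-pyrazol-3-yl with a 2.0-fold lower number from compound 2 to compound 3 (0.30 log units; within the scatter), so the two rings cannot be told apart here, although the first carries 0 hydrogen-bond donors and the second 1. A sulfur-bearing ring is not enough to match compound 1, since thiophen-2-yl to 1,3-thiazol-2-yl gives a 2.5-fold higher number from compound 1 to compound 3 (0.40 log units; beyond the scatter), and thiophen-2-yl alone stands apart from both other rings by more than the scatter. No measurement available here explains either step.

Open, from the compounds shown here alone, is whether this position stays in the same range with a six-membered ring such as pyridin-2-yl, or with a non-ring group such as an amine or a carboxylic acid. Also open, going by these compounds, is whether the order of these rings holds on any other receptor.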